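Removing the butyl chain from compound 2

The compounds below may be only part of what the source reports. "The series", "measured", "known", "first", "only" and "open" are said of these compounds alone.

Going by the values given here, compound 2 `CCCCc1cc2nn(-c3ccccc3)cc2c(C)n1` is, in a functional assay on K562 cells (Homo sapiens) for inhibition, read by fluorescence, with a stated time of 72 h (a lower number here means a stronger inhibitor of growth, a higher number a weaker inhibitor of growth), the one member of the pair that gives a number, 8500 nM. Compound 1 `Cc1nc(CCO)cc2nn(-c3ccccc3)cc12` gives only a limit in this assay, > 100000 nM, which is the limit of > 100000 nM in this assay, at which 1 of the 2 values shown sits. Among the compounds with values here, the one measured step, an at least 11-fold lower number from compound 1 to compound 2 (1.07 log units; beyond the scatter), came from ethyl in place of hydroxy on a saturated chain carbon, two bonds along the chain from an aromatic carbon. Compound 3 `Cc1nccc2nn(-c3ccccc3)cc12` differs from compound 2 by hydrogen in place of butyl on an aromatic carbon. Within the data shown here, no measured step removes the chain altogether; the only step that bears on the question is the one from compound 1 to compound 2, where a change at the end of the chain alone moved the number by at least that much. The step from compound 2 to compound 3 takes away the whole butyl, so a step in the opposite direction, towards a higher number in this assay, is expected, of comparable or larger size, with a real chance that only a limit is returned. Compound 3 is therefore estimated at 40000 nM, within 10000 nM to 150000 nM. The expected step is a 4.7-fold higher number from compound 2 to compound 3 (0.67 log units; beyond the scatter).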

Compound 3, concentration for 50% growth inhibition: > 100000 nM
Compound 3 ended at the assay's limit; the forecaster's own chance of this, stated with the estimate: 40%; at least 2.5-fold (0.39 log units) between middle value and limit.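

In this assay, going by these compounds alone, hydrogen in place of butyl on this aromatic carbon, next to the ring nitrogen, gives an at least 11-fold higher number from compound 2 to compound 3 (1.07 log units; beyond the scatter), so the whole chain, and not only its end, is now tied to the one number. The earlier step changed only the end of the chain, leaving open whether the shared core with no chain at this carbon would give a number by itself; compound 3 shows that it does not, and among the compounds shown only compound 2, with its butyl, gives a number. Compound 3 gives only a limit, as compound 1 does, so the step between these two cannot be read: the limit of > 100000 nM in this assay, at which 2 of the 3 values shown sit.

Going by these compounds, the true size of the loss on removing butyl remains unknown, as does any ranking of 2-hydroxyethyl against hydrogen at this carbon. Also open, on these data alone, is how the number would respond to a shorter chain such as propyl, a longer chain such as hexyl, a cyclohexyl ring, or an amine at the end of the butyl chain.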